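Replacing 4-fluorophenyl with 2-fluorophenyl in the series

The source may hold more compounds than are shown below. What is called first, only, known or untested is meant among the compounds shown, and "the series" means these compounds.

In a functional assay on HL-60 cells (Homo sapiens) for cytotoxicity, read by WST assay, with a stated time of 48 h (on this read-out lower numbers stand for stronger inhibition and higher numbers for weaker inhibition), compound 1 (`COc1cccc(/C=C/C[C@H]2C[C@@H]([C@@H](O)c3ccccc3)CO[C@@H]2c2ccccc2)c1`) gives 9620 nM and compound 2 (`O[C@@H](c1ccccc1)[C@H]1CO[C@H](c2ccccc2)[C@@H](C/C=C/C2CCCC2)C1`) gives 9060 nM while compound 3 (`O[C@@H](c1ccccc1)[C@H]1CO[C@H](c2ccccc2)[C@@H](C/C=C/c2ccc(F)cc2)C1`) gives 8110 nM so compound 3 stands level with the other two, all three lying within the scatter of one another.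

The change to compound 4 (`O[C@@H](c1ccccc1)[C@H]1CO[C@H](c2ccccc2)[C@@H](C/C=C/c2ccccc2F)C1`) is 2-fluorophenyl in place of 4-fluorophenyl on a double-bonded chain carbon bound to a double-bonded chain carbon.

Among the measured compounds shown here, three measured steps bear on it, all at this same place. Cyclopentyl in place of 3-methoxyphenyl gave (a 1.1-fold lower number from compound 1 to compound 2 (0.03 log units; within the scatter)) and 4-fluorophenyl in place of 3-methoxyphenyl gave (a 1.2-fold lower number from compound 1 to compound 3 (0.07 log units; within the scatter)) while 4-fluorophenyl in place of cyclopentyl gave (a 1.1-fold lower number from compound 2 to compound 3 (0.05 log units; within the scatter)) and each of these lies within the scatter. For the measured compounds named here, no measured pair compares 2-fluorophenyl with 4-fluorophenyl, so there is no direct precedent for this change.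

Given those three small steps, no step beyond the scatter is expected in this assay and no direction is favoured. The estimated step is (a 1.0-fold higher number from compound 3 to compound 4 (0.02 log units; within the scatter)) and it stays within the scatter. Compound 4 is estimated at 8500 nM with a range of 5000 nM to 14000 nM expected.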

Compound 4, half-maximal inhibitory concentration: 9530 nM
Compound 4: the middle estimate sits 1.1-fold (0.05 log units) below what was measured, within the range that was stated.
By their numbers in this assay, from the lowest: compounds 3, 2, 4 and 1 (each within the scatter of the next).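

In this assay, among the compounds shown here, 2-fluorophenyl in place of 4-fluorophenyl on a double-bonded chain carbon bound to a double-bonded chain carbon gives a 1.2-fold higher number from compound 3 to compound 4 (0.07 log units; within the scatter), the first direct comparison of two fluorophenyl groups with the same atoms joined differently at this place, and the printed step stays within the scatter. Against cyclopentyl the new group gives a 1.1-fold higher number from compound 2 to compound 4 (0.02 log units; within the scatter) and against 3-methoxyphenyl it gives a 1.0-fold lower number from compound 1 to compound 4 (0.00 log units; within the scatter), which extends the flat picture at this place to four groups, with every pair among the four compounds level in this read-out and no group order to draw from them. No supporting data accompany these numbers, and the flat reading at this place stays without an explanation.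

All four groups shown at this place are rings, and whether an amine, a carboxylic acid or a longer alkyl chain there would give a step beyond the scatter remains open. All steps shown also sit at this one place, and the effect of changes elsewhere on the shared core, such as replacing the hydroxyl group with a ketone carbonyl, remains equally open.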